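Nitro-pyrrole oxadiazoles: cytotoxicity notes before compound 4

The source may report more compounds than this note shows. Statements on the series, on what has been measured and on what is new or still open speak of the compounds shown alone.

Measured so far:
- compound 1, `Cn1cc([N+](=O)[O-])cc1-c1nnc(-c2ccco2)o1`: 191000 nM
- compound 2, `COc1ccc(-c2nnc(-c3cc([N+](=O)[O-])cn3C)o2)cc1`: 281000 nM
- compound 3, `O=[N+]([O-])c1c[nH]c(-c2nnc(Cc3ccc(F)c4ccccc34)o2)c1`: 229000 nM

The three compounds measured in an ADME assay on Vero cells (Chlorocebus sabaeus) for cytotoxicity, read by MTT assay, with a stated time of 72 h (a higher number here means a weaker inhibitor, a lower number a stronger inhibitor), sit close together. In this assay compound 1 gives 191000 nM, and compound 2 gives 281000 nM while compound 3 gives 229000 nM; the gaps from compound 1 to either neighbour fall within the usual scatter, so no separation among the three can be claimed. Among the measured compounds shown here, no single-change pairs exist among the measured compounds, so nothing is known yet about how any one substitution moves this read-out.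

Compound 4, `Cn1cc([N+](=O)[O-])cc1-c1nnc(-c2ccccc2Br)o1`, has not been measured. It differs from compound 1 in one place: 2-bromophenyl in place of furan-2-yl on an aromatic carbon. The three measured compounds already span a set of different groups on the shared core without leaving the scatter, and on that basis no step beyond the scatter is expected from compound 1 to compound 4 in this assay; the expected step is a 1.0-fold higher number from compound 1 to compound 4 (0.02 log units; within the scatter). Compound 4 is therefore estimated at 200000 nM, with a range from 100000 nM to 400000 nM.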

Compound 4, half-maximal inhibitory concentration: 303000 nM
Compound 4: middle estimate off by 1.5-fold (0.18 log units), on the low side; low and high end bracket the measured number.
By their numbers in this assay, from the lowest: compounds 1, 3, 2 and 4 (each within the scatter of the next).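

Notes on the first single-change pair: in this assay, 2-bromophenyl in place of furan-2-yl on an aromatic carbon, next to the ring nitrogen and next to the ring oxygen, gives a 1.6-fold higher number from compound 1 to compound 4 (0.20 log units; within the scatter) and so stays inside the usual scatter. At this position, a five-membered aromatic ring with 1 hetero atom and a six-membered aromatic ring of carbon only bearing bromine cannot be told apart in this read-out, despite the larger group entering and the hydrogen-bond acceptor leaving. No measurement available here bears on a cause for this step.

Open, from the compounds shown here alone, is whether an amine or a carboxylic acid at this position would give a step beyond the scatter. Also open, going by these compounds, is whether plain phenyl, without the bromine, would sit with compound 1 and compound 4.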